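This account rests on a few compounds, and the source may have more. Where it says the series, first, only, none or still open, it means among the compounds named here.

Three compounds from one series have been examined in an ADME assay (Canis lupus familiaris, strain Beagle) for pharmacokinetics; a higher number here means that more of the compound sits outside the plasma, a lower number that more of the compound stays in the plasma. Compound 1 `CCn1c(-c2cnc(C)nc2)nc2c(N[C@H]3CCN(C(=O)C4CCC4)C3)ncnc21` gives 1.3 L/kg. Compound 2 `CCC(=O)N1CC[C@H](Oc2ncnc3c2nc(-c2cnc(C)nc2)n3CC)C1` gives 1.9 L/kg. Compound 3 `CCn1c(-c2ccc(C(F)(F)F)nc2)nc2c(O[C@H]3CCN(C(=O)c4cocn4)C3)ncnc21` gives 1.2 L/kg. Its number is the smallest of the three, but the gaps to compound 1 and to compound 2 both fall within the usual scatter of repeated measurements, so the three values cannot be told apart with confidence.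

The step now goes from compound 3 to compound 4 `CCn1c(-c2ccc(C(F)(F)F)nc2)nc2c(O[C@H]3CCN(C(=O)N4CC(OC)C4)C3)ncnc21`, which has not yet been measured in this assay. The two differ in one place: 3-methoxyazetidin-1-yl in place of 1,3-oxazol-4-yl on a carbonyl carbon. Going by the values given here, no change of this kind has been measured, so there is no direct precedent to lean on.

Given that the three measured compounds, with their varied amide groups, all land in the same narrow band, the expectation for compound 4 is a step of a 1.1-fold higher number from compound 3 to compound 4 (0.03 log units; within the scatter) of no size beyond the scatter, in either direction. Compound 4 is therefore estimated at 1.3 L/kg, with a range from 0.8 L/kg to 2.1 L/kg.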

Compound 4, volume of distribution: 0.7 L/kg
Estimate against measurement, compound 4: 1.9-fold (0.27 log units) above; measured number outside the range, below it.
By their numbers in this assay, from the lowest: compounds 4, 3, 1 and 2 (each within the scatter of the next, the first and the last beyond it).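

Going by these compounds alone, compound 3 and compound 4 form the first pair that differ in one place, so the effect of a single change on a carbonyl carbon can now be read directly. In this assay, putting 3-methoxyazetidin-1-yl in place of 1,3-oxazol-4-yl gives a 1.7-fold lower number from compound 3 to compound 4 (0.23 log units; within the scatter), so even replacing a five-membered aromatic ring with a four-membered non-aromatic one does not produce a step beyond the scatter. Nothing measured here bears on how either group acts on this read-out.

Going by these compounds, it remains open whether a plain azetidin-1-yl without the methoxy, or a carboxylic acid at the same place, would give a step beyond the scatter. On these data alone, it is also open whether the same change would give a similar step on the core of compound 1.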